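Compound 1 to compound 4: change on the carbonyl carbon

The compounds below may be only part of what the source reports. "The series", "measured", "known", "first", "only" and "open" are said of these compounds alone.

In a functional assay on HepG2 cells (Homo sapiens) for inhibition, read by MTT assay, with a stated time of 24 h (on this read-out lower numbers stand for stronger inhibition and higher numbers for weaker inhibition), compound 1 (`Cc1ccc(C(=O)NCC(=O)N/N=C/c2ccccc2OCc2ccccc2Cl)cc1`) gives 13400 nM and holds the lower of the two numbers in hand. Compound 2 (`C[C@]1(C(=O)NCCOc2ccc(C3CCCCC3)cc2)CO[C@@H](c2ccccc2)OC1`) gives 32900 nM by comparison. Compound 3 (`Cc1ccc(C(=O)NCC(=O)N/N=C/c2ccccc2OCc2ccc(C#N)cc2)cc1`) gives > 50000 nM as a limit of the assay, not a number. Compound 4 (`O=C(CNC(=O)c1cccnc1Cl)N/N=C/c1ccccc1OCc1ccccc1Cl`) carries 2-chloropyridin-3-yl in place of 4-methylphenyl on a carbonyl carbon. Among the measured compounds shown here, no step at this place has been measured. For the measured compounds named here, the only measured step, an at least 3.7-fold higher number from compound 1 to compound 3 (0.57 log units; beyond the scatter) for 4-cyanophenyl in place of 2-chlorophenyl, lies elsewhere in the molecule and bears only loosely on this change. The expected step is a 1.3-fold higher number from compound 1 to compound 4 (0.13 log units; within the scatter) and stays within the scatter. The estimate for compound 4 is 18000 nM in this assay and repeat measurements are expected between 6000 nM and 45000 nM on this reading.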

Compound 4, half-maximal inhibitory concentration: 16900 nM
The estimate for compound 4 lay 1.1-fold (0.03 log units) above the measured number; the measured number falls inside the stated range.
By their numbers in this assay, from the lowest: compounds 1, 4 and 2 (each within the scatter of the next, the first and the last beyond it). At a limit, above all of these: compound 3.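

In this assay, the first step read on the carbonyl carbon is a 1.3-fold higher number from compound 1 to compound 4 (0.10 log units; within the scatter), so this one pair separates 2-chloropyridin-3-yl from 4-methylphenyl by no more than repeat measurements would. Among the compounds shown here, the one step beyond the scatter remains the change on the saturated chain carbon, an at least 3.7-fold higher number from compound 1 to compound 3 (0.57 log units; beyond the scatter). Nothing measured here bears on why this exchange leaves the number within the scatter.

Open, as far as these compounds go, is whether a carboxylic acid or a saturated amine on this carbonyl carbon would hold the number. Also open, from the compounds shown here alone, is whether 2-chloropyridin-3-yl would read the same alongside 4-cyanophenyl.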